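Lengthening the chain on the core: from propyl to butyl

The source may report more compounds than this note shows. Statements on the series, on what has been measured and on what is new or still open speak of the compounds shown alone.

Measured compounds:
- compound 1, `CCCn1c(=O)[nH]c(=O)c2c1ncn2CC`: in an assay on membranes from brain for displacement of a labelled ligand from adenosine receptor A1 (Cavia porcellus) (a higher number here means a weaker inhibitor, a lower number a stronger inhibitor), compound 1 gives 40400 nM
- compound 2, `CCCn1cnc2c1c(=O)[nH]c(=O)n2CCC`: in this assay compound 2 gives 18200 nM

Within the data shown here, compound 2 holds the lowest number of the two measured compounds, with compound 1 as its only neighbour; the single measured step reads a 2.2-fold lower number from compound 1 to compound 2 (0.35 log units; beyond the scatter). Compound 3, `CCCCn1cnc2c1c(=O)[nH]c(=O)n2CCC`, is not yet measured. It differs from compound 2 in one place: methyl in place of hydrogen on a saturated chain carbon, three bonds along the chain from an aromatic nitrogen. Seen from the whole chain, this is propyl to butyl on the same nitrogen that carried ethyl in compound 1 and propyl in compound 2.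

Among the measured compounds shown here, the only step that bears on this change is the one from compound 1 to compound 2, which also added one carbon at the end of that chain. Read on its own, it suggests that a further carbon might lower the number again, though nothing in the two measured values shows whether the effect continues, stalls or turns. Compound 3 is therefore expected to lie modestly below compound 2, with the step estimated as a 1.7-fold lower number from compound 2 to compound 3 (0.22 log units; within the scatter). The estimate for compound 3 is 11000 nM, expected between 5000 nM and 30000 nM.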

Compound 3, inhibition constant: 12100 nM
Compound 3: the middle estimate sits 1.1-fold (0.04 log units) below what was measured; the range from low to high includes it.
By their numbers in this assay, from the lowest: compounds 3 and 2 (each within the scatter of the next); then compound 1.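

In this assay, going from propyl to butyl on this nitrogen gives a 1.5-fold lower number from compound 2 to compound 3 (0.18 log units; within the scatter), so this added carbon, unlike the step from ethyl to propyl, does not separate the two compounds beyond the scatter. Over the whole change from ethyl to butyl, the record reads a 3.3-fold lower number from compound 1 to compound 3 (0.52 log units; beyond the scatter), which is a modest step that clears the scatter, while the propyl and butyl chains cannot be told apart in this assay. No evidence is at hand to explain these numbers.

The compounds shown leave open whether a longer chain, such as pentyl or hexyl, on this nitrogen would move the number beyond the scatter from compound 3 or whether the values have levelled off. They also leave open how a branched chain such as isobutyl, a benzyl group or a chain carrying an amine would read on this nitrogen, and whether the other propyl chain on the shared core would respond to lengthening in the same way.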